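The source may hold more compounds than are shown below. What is called first, only, known or untested is meant among the compounds shown, and "the series" means these compounds.

Compound 3 `C[C@@H]1CC[C@H](NC(=O)[C@H](CC2CCC(C)(C)CC2)NC(=O)c2ccco2)C(=O)CN1S(=O)(=O)c1ccccn1` sits second highest of the three numbers recorded in an assay on isolated protein for inhibition of cathepsin S (Homo sapiens), read by fluorescence; a higher number here means a weaker inhibitor, a lower number a stronger inhibitor: compound 3 gives 1.2 nM, while compound 1 `CC1CCC(C[C@H](NC(=O)c2ccco2)C(=O)N[C@H]2CC[C@@H](C)N(S(=O)(=O)c3ccccn3)CC2=O)CC1` gives 0.5 nM and compound 2 `C[C@@H]1CC[C@H](NC(=O)[C@H](CC2=CCCC2)NC(=O)c2ccco2)C(=O)CN1S(=O)(=O)c1ccccn1` gives 4.9 nM. The steps at the same place are a 9.8-fold higher number from compound 1 to compound 2 (0.99 log units; beyond the scatter) and a 4.1-fold lower number from compound 2 to compound 3 (0.61 log units; beyond the scatter), and elsewhere a 2.4-fold higher number from compound 1 to compound 3 (0.38 log units; beyond the scatter). Compound 4 `C[C@@H]1CC[C@H](NC(=O)[C@H](CC(C)(C)C)NC(=O)c2ccco2)C(=O)CN1S(=O)(=O)c1ccccn1` carries tert-butyl in place of 4,4-dimethylcyclohexyl on a saturated chain carbon, two bonds along the chain from an amide-type nitrogen and a carbonyl carbon, a change that removes the ring altogether. Since the smaller cyclopent-1-en-1-yl in compound 2 reads weaker, as seen in a 4.1-fold lower number from compound 2 to compound 3 (0.61 log units; beyond the scatter), a comparable weakening is expected here, so the step of a 5.0-fold higher number from compound 3 to compound 4 (0.70 log units; beyond the scatter) is the estimate. Compound 4 is therefore expected to give about 6 nM in this assay, within a range of 1.5 nM to 25 nM.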

Compound 4, half-maximal inhibitory concentration: 1.3 nM
Beside the measured number, compound 4's estimate is 4.6-fold (0.66 log units) above it, outside the stated range (below it).
By their numbers in this assay, from the lowest: compound 1; then compounds 3 and 4 (each within the scatter of the next); then compound 2.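

In this assay, a ring at this position proves unnecessary for a low-nanomolar number: tert-butyl, with no ring, matches 4,4-dimethylcyclohexyl (a 1.1-fold higher number from compound 3 to compound 4 (0.03 log units; within the scatter)). Yet the ring groups are not interchangeable, since tert-butyl reads stronger than cyclopent-1-en-1-yl (a 3.8-fold lower number from compound 2 to compound 4 (0.58 log units; beyond the scatter)) and weaker than 4-methylcyclohexyl (a 2.6-fold higher number from compound 1 to compound 4 (0.41 log units; beyond the scatter)), so size alone does not order these compounds. No evidence is available that accounts for these differences. The compounds shown leave open how isopropyl or a plain methyl would read here, and whether an amine on this chain would be accepted.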